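From Compound 3 to Compound 4: An Expected Fall

The source may hold more compounds than are shown below. What is called first, only, known or untested is meant among the compounds shown, and "the series" means these compounds.

Compound 1 `NC(=O)CCn1nc(-c2ccccc2)ccc1=O`: -2.8%
Compound 2 `Cc1ccc(=O)n(CC(=N)S)n1`: 31.5%
Compound 3 `Cc1ccc(=O)n(CCCCC(=N)S)n1`: 29.5%

In a functional assay on the whole organism (stomach) for inhibition, with Rattus norvegicus as the target, at a dose of 100 mg/kg by the intraduodenal route (on this read-out lower numbers stand for less inhibition and higher numbers for more inhibition at the one dose given (going by the name of the read-out)), compound 3 gives 29.5%, the second highest of the three numbers. Compound 2 at 31.5% sits within the usual scatter of it, whereas compound 1 at -2.8% lies far lower, beyond the scatter. Compound 4 `Cc1ccc(=O)n(CCC(N)=O)n1` differs from compound 3 by a group of 3 heavy atoms (1 carbon, 1 nitrogen, 1 oxygen; no ring) in place of a group of 5 heavy atoms (3 carbon, 1 nitrogen, 1 sulfur; no ring), on a saturated chain carbon, two bonds along the chain from an aromatic nitrogen. Within the data shown here, no measured pair shows this exact change, but a carbamoyl group also sits on the chain of compound 1, and that compound is the one near zero. A fall beyond the scatter is therefore expected, as the step of a number 21.5 percentage points lower from compound 3 to compound 4 (beyond the scatter) in this assay. Compound 4 is estimated at 8%, with a range from -10% to 28%.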

Compound 4, a percentage reported as inhibition, in the whole organism at one dose (the size of the read-out at that dose, not a potency): -2.9%
For compound 4 the middle estimate is 10.9 percentage points above the measured one; the measured number falls inside the stated range.
By their numbers in this assay, from the lowest: compounds 4 and 1 (each within the scatter of the next); then compounds 3 and 2 (each within the scatter of the next).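

Carbamoyl in place of the sulfur-containing group gives a number 32.4 percentage points lower from compound 3 to compound 4 (beyond the scatter) in this assay, and the comparison on the saturated chain carbon bound to an aromatic nitrogen gives a number 34.4 percentage points lower from compound 2 to compound 4 (beyond the scatter). With carbamoyl on the chain, methyl in place of phenyl on an aromatic carbon gives a number 0.1 percentage points lower from compound 1 to compound 4 (within the scatter), so this change on the core does not restore the read-out. Nothing measured here gives a reason for the fall.

As far as these compounds go, whether the fall reflects losing the sulfur-containing group or gaining carbamoyl stays open. A carboxylic acid or an amine in the same place could help separate the two.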